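From dimethylamino to methyl on the side chain

This account rests on a few compounds, and the source may have more. Where it says the series, first, only, none or still open, it means among the compounds named here.

In a functional assay on MCF7 cells (Homo sapiens) for cytotoxicity, read by MTT assay, with a stated time of 72 h (on this read-out higher numbers stand for weaker inhibition and lower numbers for stronger inhibition), two compounds have been measured:
Compound 1 `COc1ncc(-c2ccc3nc(NC(=O)NCC(=O)N4CCCCC4)nn3c2)cc1NS(=O)(=O)c1ccc(F)cc1` gives 570 nM
Compound 2 `COc1ncc(-c2ccc3nc(NC(=O)NCCN(C)C)nn3c2)cc1NS(=O)(=O)c1ccc(F)cc1` gives 560 nM

Compound 2 stands level with compound 1, within the scatter. Compound 3 `CCCNC(=O)Nc1nc2ccc(-c3cnc(OC)c(NS(=O)(=O)c4ccc(F)cc4)c3)cn2n1` differs from compound 2 by one change (methyl in place of dimethylamino on a saturated chain carbon, two bonds along the chain from an amide-type nitrogen): methyl in place of dimethylamino on a saturated chain carbon, two bonds along the chain from an amide-type nitrogen. For the measured compounds named here, the only measured step on this chain (a 1.0-fold lower number from compound 1 to compound 2 (0.01 log units; within the scatter)) lies within the scatter, so no step beyond the scatter is expected in this assay here. The expected step (a 1.1-fold lower number from compound 2 to compound 3 (0.05 log units; within the scatter)) stays within the scatter. For compound 3 the estimated value is 500 nM (expected range 180 nM to 1400 nM).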

Compound 3, half-maximal inhibitory concentration: 360 nM
Beside the measured number, compound 3's estimate is 1.4-fold (0.14 log units) above it, and the stated range covers the measured number.
By their numbers in this assay, from the lowest: compounds 3, 2 and 1 (each within the scatter of the next).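

In this assay, methyl in place of dimethylamino gives a 1.6-fold lower number from compound 2 to compound 3 (0.19 log units; within the scatter) on this side chain, and ethyl in place of (piperidin-1-yl)carbonyl gives a 1.6-fold lower number from compound 1 to compound 3 (0.20 log units; within the scatter) across the same stretch. Thus, a plain propyl group, with no nitrogen or carbonyl at its end, stands level with both earlier compounds, which the first pair of side chains, both carrying such a group, could not show. Nothing available explains this level result.

On these data alone, how a carboxylic acid or a longer chain such as hexyl would read at this place remains open.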